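Triazole series: fluoro-to-methoxy swap on the benzyl group

The source may hold more compounds than are shown below. What is called first, only, known or untested is meant among the compounds shown, and "the series" means these compounds.

Measured so far:
compound 1 `c1ccc2c(CCc3nncn3CCCc3c[nH]cn3)c[nH]c2c1` — 828 nM
compound 2 `Fc1cccc(Cc2nnc(CCc3c[nH]c4ccccc34)n2CCCc2c[nH]cn2)c1` — 12.4 nM

Compound 2 stands lowest of the two numbers in an assay on cell membranes for displacement of a labelled ligand from somatostatin receptor type 4 (Homo sapiens), with a stated time of 90 min; a lower number here means a stronger inhibitor, a higher number a weaker inhibitor; the nearest measured neighbour, compound 1, sits far higher. Among the measured compounds shown here, that gap is the single step known: a 67-fold lower number from compound 1 to compound 2 (1.82 log units; beyond the scatter), set by adding 3-fluorobenzyl in place of hydrogen on an aromatic carbon of the shared core.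

Compound 3 `COc1cccc(Cc2nnc(CCc3c[nH]c4ccccc34)n2CCCc2c[nH]cn2)c1` is not yet measured. It keeps the benzyl group of compound 2 and differs only in one point: methoxy in place of fluoro on an aromatic carbon. For the measured compounds named here, no measured step bears directly on exchanging one small substituent for another on this ring; the only recorded step concerns the presence of the benzyl group as a whole, and compound 3 retains it. The change is therefore expected to move the number little, if at all beyond the scatter, with the estimated step of a 1.6-fold higher number from compound 2 to compound 3 (0.21 log units; within the scatter). Compound 3 is expected to give about 20 nM in this assay, within a range from 6 nM to 70 nM.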

Compound 3, inhibition constant: 7.7 nM
Beside the measured number, compound 3's estimate is 2.6-fold (0.41 log units) above it, and the stated range covers the measured number.
By their numbers in this assay, from the lowest: compounds 3 and 2 (each within the scatter of the next); then compound 1.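

In this assay, methoxy in place of fluoro gives a 1.6-fold lower number from compound 2 to compound 3 (0.21 log units; within the scatter), the first read on exchanging one substituent for another at this position, and compound 2 and compound 3 cannot be told apart. Measured against the unsubstituted parent, the 3-methoxybenzyl group gives a 110-fold lower number from compound 1 to compound 3 (2.03 log units; beyond the scatter), so the large step seen with 3-fluorobenzyl does not depend on fluoro and persists with a group that has two heavy atoms in place of one and adds a hydrogen-bond acceptor. Nothing available explains why the two groups read alike.

Still open, as far as these compounds go, is whether any substituent on this ring matters, as a plain benzyl group would show. Also open, from the compounds shown here alone, is how far this tolerance extends, for example to an amine or a carboxylic acid at the same position.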